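Removing the Nitro Group from Compound 2

The source may hold more compounds than are shown below. What is called first, only, known or untested is meant among the compounds shown, and "the series" means these compounds.

Within the data shown here, compound 2 `O=c1cc(/C=N\Nc2ccc([N+](=O)[O-])cc2)c2c(OCc3ccccc3)cc(OCc3ccccc3)cc2o1` gives 15500 nM in a functional assay, read by spectrophotometry, with a stated time of 3 min (a lower number here means a stronger inhibitor, a higher number a weaker inhibitor), the higher of the two numbers known; compound 1 `O=c1cc(/C=N\c2ccc(O)cc2)c2c(OCc3ccccc3)cc(OCc3ccccc3)cc2o1` gives 3570 nM, and the step of a 4.3-fold higher number from compound 1 to compound 2 (0.64 log units; beyond the scatter) separates them. Compound 3 `O=c1cc(/C=N\Nc2ccccc2)c2c(OCc3ccccc3)cc(OCc3ccccc3)cc2o1` differs from compound 2 by hydrogen in place of nitro on an aromatic carbon. Among the measured compounds shown here, no measured step bears directly on this change: the single step known swaps (4-nitrophenyl)amino for 4-hydroxyphenyl and so alters two things at once. The nitro removal alone is therefore expected to give only a small step, a 1.6-fold lower number from compound 2 to compound 3 (0.19 log units; within the scatter), with a weak lean toward a lower number. Compound 3 is estimated at 10000 nM, within 3000 nM to 30000 nM.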

Compound 3, half-maximal inhibitory concentration: 40100 nM
The estimate for compound 3 lay 4.0-fold (0.60 log units) below the measured number; measured number outside the range, above it.
By their numbers in this assay, from the lowest: compound 1; then compound 2; then compound 3.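

In this assay, taking away the nitro group weakens inhibition rather than leaving it unchanged (a 2.6-fold higher number from compound 2 to compound 3 (0.41 log units; beyond the scatter)), so on this aromatic carbon the nitro group gives the stronger inhibitor of the two. With neither substituent on the anilino ring, the gap to the 4-hydroxyphenyl compound also widens (an 11-fold higher number from compound 1 to compound 3 (1.05 log units; beyond the scatter)), and the earlier pair had hidden how much of that gap belongs to the nitro group. Nothing available here accounts for the direction of this change. The compounds shown leave open whether an amino group or a methoxy group on this carbon would fall nearer compound 2 or compound 3.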